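Pyridyl Ether Swap on a Cyanopyridone Modulator Core

A few compounds are considered here, and "the series" means these few. Any claim that something is new, unique, unknown or untested is made for them only; others in the source may bear on it.

Compound 1 `CC(C)CCn1ccc(-c2ccc(Oc3ccccc3)cc2)c(C#N)c1=O` gives 42 nM in a functional assay on CHO cells for positive allosteric modulation of metabotropic glutamate receptor 2 (Homo sapiens), read by scintillation counting and GTPgammaS binding, with a stated time of 30 min; on this read-out lower numbers stand for an effect already at smaller amounts and higher numbers for an effect only at larger amounts of compound.
Compound 2 `CNc1ccc(-c2ccn(CCC(C)C)c(=O)c2C#N)cc1` gives 460 nM in this assay.
Compound 3 `Cc1cc(Oc2ccc(-c3ccn(CCC(C)C)c(=O)c3C#N)cc2)ccn1` gives 447 nM in this assay.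

Compound 3 stands second highest of the three numbers in this assay; compound 2 lies within the scatter of it, and compound 1 far apart, as an 11-fold higher number from compound 1 to compound 3 (1.03 log units; beyond the scatter) shows. Compound 4 `Cc1ccc(Oc2ccc(-c3ccn(CCC(C)C)c(=O)c3C#N)cc2)c(C)n1` differs from compound 3 by 2,6-dimethylpyridin-3-yl in place of 2-methylpyridin-4-yl on an oxygen on an aromatic ring. Among the measured compounds shown here, neither an 11-fold higher number from compound 1 to compound 3 (1.03 log units; beyond the scatter) nor a 1.0-fold lower number from compound 2 to compound 3 (0.01 log units; within the scatter) swaps one pyridyl for another, so no measured step bears directly on this change; both enter and leave groups are single aromatic rings with one acceptor. A step within the scatter in this assay is therefore expected. Compound 4 is estimated at 420 nM, within 150 nM to 1200 nM. The estimated step reads a 1.1-fold lower number from compound 3 to compound 4 (0.03 log units; within the scatter).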

Compound 4, half-maximal effective concentration: 100 nM
Compound 4: the middle estimate sits 4.2-fold (0.62 log units) above what was measured; measured number below the stated range.
By their numbers in this assay, from the lowest: compound 1; then compound 4; then compounds 3 and 2 (each within the scatter of the next).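

On the oxygen, the choice of pyridyl group matters in this assay, as a swap between two such groups gives a 4.5-fold lower number from compound 3 to compound 4 (0.65 log units; beyond the scatter) and so moves the number beyond the scatter. The 2,6-dimethylpyridin-3-yl ether also separates from the methylamino compound, with a 4.6-fold lower number from compound 2 to compound 4 (0.66 log units; beyond the scatter), yet it does not match phenyl on the same oxygen, with a 2.4-fold higher number from compound 1 to compound 4 (0.38 log units; beyond the scatter) in that comparison. No evidence at hand explains the difference between the two pyridyl groups.

The lower number could go with the added methyl or with the change from pyridin-4-yl to pyridin-3-yl, since both arrive together. A plain pyridin-3-yl group on the oxygen would separate the two.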